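Propargyl thioether in place of a chloroaryl ketone

A few compounds are considered here, and "the series" means these few. Any claim that something is new, unique, unknown or untested is made for them only; others in the source may bear on it.

Measured compounds:
compound 1, `C#CCSc1nnc(C)n1N1C(=O)c2ccccc2C1=O`, > 200000 nM
compound 2, `CCCc1nnc(SCC(=O)c2ccc(Cl)cc2)n1N1C(=O)c2ccccc2C1=O`, > 200000 nM

In a functional assay on PC-3M cells (Homo sapiens) for cytotoxicity, read by MTT assay, with a stated time of 48 h (a lower number here means a stronger inhibitor, a higher number a weaker inhibitor), compound 2 gives only a limit, > 200000 nM. Compound 1 likewise reaches only a limit in this assay. Among the compounds with values here, both values therefore rest at the limit of > 200000 nM in this assay, at which 2 of the 2 values shown sit, so no measured step between them can be counted.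

Compound 3, `C#CCSc1nnc(CCC)n1N1C(=O)c2ccccc2C1=O`, differs from compound 2 in one place: ethynyl in place of (4-chlorophenyl)carbonyl on a saturated chain carbon bound to a sulfur. The resulting propargyl thioether of compound 3 is the same group that compound 1 carries, with the propyl of compound 2 retained on the core.

Because compound 2 sits at > 200000 nM and compound 1 sits at > 200000 nM, no change beyond the scatter is expected from this substitution; the expected step is a step that the limit leaves unreadable from compound 2 to compound 3. Compound 3 is estimated at 250000 nM in this assay, within 100000 nM to 600000 nM, most likely reported as a limit.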

Compound 3, half-maximal inhibitory concentration: > 200000 nM
Compound 3: only a limit was reported; the forecaster's own chance of this, stated with the estimate: 85%; the middle value lies beyond the limit too.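

Compound 3 also gives only a limit, > 200000 nM, in this assay. The steps from compound 1 and from compound 2 to compound 3 therefore cannot be read: the limit of > 200000 nM in this assay, at which 3 of the 3 values shown sit.

The compounds shown leave open whether any group on the shared core would give a readable value in this assay.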